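The source may hold more compounds than are shown below. What is called first, only, known or untested is meant among the compounds shown, and "the series" means these compounds.

Measured compounds and their numbers:
compound 1, `COc1cc2ncnc(Nc3cc(C(F)(F)F)ccc3F)c2c(OC)c1OC`: 7.6%
compound 2, `COc1cc2ncnc(Nc3ccc([N+](=O)[O-])cc3)c2c(OC)c1OC`: 7.9%
compound 3, `COc1cc2ncnc(Nc3cc(F)ccc3Br)c2c(OC)c1OC`: 12.8%

All three share one core and differ only in the aromatic ring attached through the amine. In a functional assay on PC-3 cells (Homo sapiens) for inhibition, read by MTT assay, with a stated time of 72 h, tested at 1 uM (on this read-out lower numbers stand for less inhibition of growth and higher numbers for more inhibition of growth at the one concentration tested), compound 2 gives 7.9%. That number lies within the usual scatter of the numbers of compound 1 and of compound 3, so the three compounds cannot be told apart on this read-out; each of them leaves most of the cell growth untouched at the single concentration tested.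

Compound 4, `COc1cc2ncnc(Nc3ccc(F)cc3)c2c(OC)c1OC`, has not been measured yet. Compared with compound 2, the change is fluoro in place of nitro on an aromatic carbon. Within the data shown here, no pair of measured compounds differs in a single place, so there is no measured step to lean on. Because the nitro-bearing compound 2 gives 7.9% and the two fluorine-bearing compounds 1 and 3 also sit at low inhibition within the scatter, no step beyond the scatter is expected in this assay, in either direction. Compound 4 is therefore expected to give about 9%, with a range from 0% to 20%. The step this estimate implies, a number 1.1 percentage points higher from compound 2 to compound 4 (within the scatter), is expected to be essentially none.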

Compound 4, percent growth inhibition at one concentration: 3.1%
For compound 4 the middle estimate is 5.9 percentage points above the measured one; the range from low to high includes it.
By their numbers in this assay, from the lowest: compounds 4, 1, 2 and 3 (each within the scatter of the next).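

In this assay, among these compounds, replacing nitro with fluoro on this aromatic carbon, para to a large group, gives the first step at this place that changes a single group, and that step is a number 4.8 percentage points lower from compound 2 to compound 4 (within the scatter) and so cannot be told apart from repeat-to-repeat variation. A larger change, 4-fluorophenyl in place of 2-bromo-5-fluorophenyl on the nitrogen, gives a number 9.7 percentage points lower from compound 3 to compound 4 (within the scatter) in this assay and is just as unreadable as a real difference, so neither swapping one group nor rebuilding the substitution on this aromatic ring has yet produced a clear effect. No measurement of any property of these groups bears on these steps.

On these data alone, all four compounds leave most cell growth untouched at the one concentration tested, so it remains open whether any group at this place can move the number clearly beyond the scatter. An amine or a carboxylic acid on the same aromatic carbon, or a longer chain there, would test whether this position responds at all to a group quite unlike nitro and fluoro.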